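Replacing the 2-propylphenyl group of compound 2

A few compounds are considered here, and "the series" means these few. Any claim that something is new, unique, unknown or untested is made for them only; others in the source may bear on it.

In a functional assay on ileum (Cavia porcellus) for antagonist activity, with a stated time of 30 s (on this read-out higher numbers stand for weaker inhibition and lower numbers for stronger inhibition), compound 1 `CCCc1ccccc1OCC(O)COc1ccc2c(=O)cc(C(=O)O)oc2c1` gives 2 ug/mL, and compound 2 `CCCc1ccccc1OCC(O)COc1ccc2c(=O)cc(C(=O)O)oc2c1CCC` gives 0.044 ug/mL. The number for compound 2 is the lower of the two and so stands for the stronger inhibition. Among the measured compounds shown here, the single measured change between them is a 45-fold lower number from compound 1 to compound 2 (1.66 log units; beyond the scatter), a large step beyond the scatter, with propyl in place of hydrogen on an aromatic carbon.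

Compound 3 `CCCc1c(OCC(O)COc2cccc(O)c2C(C)=O)ccc2c(=O)cc(C(=O)O)oc12` keeps that propyl and changes elsewhere: a group of 10 heavy atoms (8 carbon, 2 oxygen; one six-membered aromatic ring of carbon only) in place of a group of 9 heavy atoms (9 carbon; one six-membered aromatic ring of carbon only), on an oxygen on a saturated carbon. The 2-propylphenyl group leaves, and a group with no common name enters, on an oxygen on a saturated carbon. For the measured compounds named here, no measured step touches this place. The step of a 45-fold lower number from compound 1 to compound 2 (1.66 log units; beyond the scatter) therefore bears only indirectly: it shows that one change can move the number a long way in this assay, but it gives no direction for this exchange.

With nothing pointing either way, what is expected is a 1.1-fold higher number from compound 2 to compound 3 (0.06 log units; within the scatter), which means no step beyond the scatter, although the range must stay wide. Compound 3 is estimated at 0.05 ug/mL, with an expected range from 0.01 ug/mL to 0.3 ug/mL.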

Compound 3, half-maximal inhibitory concentration: 0.3 ug/mL
Estimate against measurement, compound 3: 6.0-fold (0.78 log units) below; the measured number falls inside the stated range.
By their numbers in this assay, from the lowest: compound 2; then compound 3; then compound 1.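

In this assay, exchanging the 2-propylphenyl group for the group with no common name gives a 6.8-fold higher number from compound 2 to compound 3 (0.83 log units; beyond the scatter), a modest step beyond the scatter. Among the compounds shown here, this is the first reading at this place on an oxygen on a saturated carbon, and it shows that the number responds to what stands there, here in the direction of weaker inhibition, whereas the earlier step spoke only for propyl in place of hydrogen on an aromatic carbon. The information available gives no explanation for this shift.

The entering group keeps a six-membered aromatic ring of carbon only but differs from the leaving group in its oxygens, its double bond outside aromatic rings and its hydrogen-bond donor and acceptors, so the compounds shown leave open which of these features goes with the step. Also open, on these data alone, is how the number would respond to an amine on that ring, or to a butyl chain in place of the propyl of the 2-propylphenyl group, and whether the large gain from the aromatic propyl would hold with the new group in place.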